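The source may hold more compounds than are shown below. What is called first, only, known or untested is meant among the compounds shown, and "the series" means these compounds.

Measured so far:
compound 1 `COCc1cccc(C[C@H](O)/C=C/[C@H]2[C@H](O)CC(=O)[C@@H]2SCCCSCC(=O)O)c1` gives 2100 nM in an assay on CHO cells for displacement of a labelled ligand from prostaglandin E2 receptor EP2 subtype (Mus musculus); on this read-out higher numbers stand for weaker inhibition and lower numbers for stronger inhibition
compound 2 `COc1ccccc1C[C@H](O)/C=C/[C@H]1[C@H](O)CC(=O)[C@@H]1SCCCSCC(=O)O` gives 2600 nM in this assay

Compound 2 holds the highest of the two numbers in this assay, yet a 1.2-fold higher number from compound 1 to compound 2 (0.09 log units; within the scatter) lies within the scatter, so the two are not separated. Compound 3 `COc1ccc(C[C@H](O)/C=C/[C@H]2[C@H](O)CC(=O)[C@@H]2SCCCSCC(=O)O)cc1` differs from compound 2 by 4-methoxyphenyl in place of 2-methoxyphenyl on a saturated chain carbon, two bonds along the chain from a double-bonded chain carbon and an oxygen on a saturated carbon. Among the compounds with values here, the only measured step, a 1.2-fold higher number from compound 1 to compound 2 (0.09 log units; within the scatter), also exchanged one methoxy-bearing aryl group for another and moved nothing beyond the scatter; the step of a 1.2-fold lower number from compound 2 to compound 3 (0.07 log units; within the scatter) is therefore expected to show no size beyond the scatter. Compound 3 is estimated at 2200 nM, range 800 nM to 6000 nM.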

Compound 3, inhibition constant: 1500 nM
Beside the measured number, compound 3's estimate is 1.5-fold (0.17 log units) above it; the measured number falls inside the stated range.
By their numbers in this assay, from the lowest: compounds 3, 1 and 2 (each within the scatter of the next).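

Placing 4-methoxyphenyl where 2-methoxyphenyl stood gives a 1.7-fold lower number from compound 2 to compound 3 (0.24 log units; within the scatter), and placing it where 3-(methoxymethyl)phenyl stood gives a 1.4-fold lower number from compound 1 to compound 3 (0.15 log units; within the scatter), so neither step leaves the scatter in this assay. Rearranging the same atoms on this saturated chain carbon therefore separates no pair among the three aryl groups, extending the earlier single comparison to all three compounds. No available evidence bears on this result.

Still open, as far as these compounds go, is whether an aminomethyl or carboxylic acid group on this aryl ring, or a longer chain in place of the benzyl group, would give a step beyond the scatter.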